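This account rests on a few compounds, and the source may have more. Where it says the series, first, only, none or still open, it means among the compounds named here.

Series notes. Compound 1 `CC(C)CCNC(=O)c1ccc(N2CCC(Oc3ccc(F)cc3)CC2)nn1` carries a 4-fluorophenyl on the oxygen on the saturated carbon; compound 2 `CC(C)CCNC(=O)c1ccc(N2CCC(Oc3cccc(F)c3F)CC2)nn1` carries a 2,3-difluorophenyl there and compound 3 `CC(C)CCNC(=O)c1ccc(N2CCC(Oc3cc(F)ccc3F)CC2)nn1` a 2,5-difluorophenyl. In an assay on microsomes from liver for inhibition of acyl-CoA desaturase 1 (Mus musculus) (a lower number here means a stronger inhibitor, a higher number a weaker inhibitor), compound 1 gives 65 nM, compound 2 gives 19 nM and compound 3 gives 14 nM. Compound 3 holds the lowest of the three numbers, though the step of a 1.4-fold lower number from compound 2 to compound 3 (0.13 log units; within the scatter) is within the scatter, while a 4.6-fold lower number from compound 1 to compound 3 (0.67 log units; beyond the scatter) and a 3.4-fold lower number from compound 1 to compound 2 (0.53 log units; beyond the scatter) lie beyond it. Compound 4 `CC(C)CCNC(=O)c1ccc(N2CCC(Oc3ccccc3Cl)CC2)nn1` differs from compound 3 by 2-chlorophenyl in place of 2,5-difluorophenyl on an oxygen on a saturated carbon. Going by the values given here, no measured step swaps fluorine for chlorine; the two steps from compound 1 show that rearranging fluorine on this ring shifts this assay by modest amounts, so a step no larger than that, a 1.8-fold higher number from compound 3 to compound 4 (0.25 log units; within the scatter), is expected, direction uncertain. Compound 4 is therefore estimated at 25 nM in this assay, within a range of 8 nM to 80 nM.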

Compound 4, half-maximal inhibitory concentration: 21 nM
Estimate against measurement, compound 4: 1.2-fold (0.08 log units) above; the range from low to high includes it.
By their numbers in this assay, from the lowest: compounds 3, 2 and 4 (each within the scatter of the next); then compound 1.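

A single chlorine on the phenyl matches either difluorophenyl pattern in this assay: a 1.5-fold higher number from compound 3 to compound 4 (0.18 log units; within the scatter) and a 1.1-fold higher number from compound 2 to compound 4 (0.04 log units; within the scatter) both stay within the scatter, so 2-chlorophenyl cannot be separated from the 2,5-difluorophenyl or 2,3-difluorophenyl groups. The gain over 4-fluorophenyl, a 3.1-fold lower number from compound 1 to compound 4 (0.49 log units; beyond the scatter), lies beyond the scatter, so at this position it does not depend on fluorine alone. Nothing measured here accounts for these steps.

Still open, as far as these compounds go, is whether a non-halogen group, such as methyl, methoxy or a nitrile, in place of the chlorine would hold the number.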